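This account rests on a few compounds, and the source may have more. Where it says the series, first, only, none or still open, it means among the compounds named here.

Compound 1 `CCCC(=O)N1CC2CC(C1)N2` gives 110% in an assay on SH-EP1 cells for agonist activity at Neuronal acetylcholine receptor; alpha4/beta2 (Homo sapiens), read by FLIPR and calcium flux; on this read-out higher numbers stand for larger maximal responses and lower numbers for smaller maximal responses. Compound 2 `CC(C)C(=O)N1CC2CC(C1)N2` gives 71%. Compound 3 `O=C(C1CCCC1)N1CC2CC(C1)N2` gives 68%.

Compound 2 stands second highest of these three numbers, within the scatter of compound 3 and beyond the scatter below compound 1. Compound 4 `O=C([C@@H]1C[C@@H]1F)N1CC2CC(C1)N2` differs from compound 2 by 2-fluorocyclopropyl in place of isopropyl on a carbonyl carbon. Within the data shown here, the one measured step at that carbonyl carbon is a number 39 percentage points lower from compound 1 to compound 2 (beyond the scatter), and compound 3 shows that a ring on the same carbon sits close to compound 2. Compound 4 is therefore expected to stay near compound 2, with a step of a number 6 percentage points lower from compound 2 to compound 4 (within the scatter) that is estimated to lie within the scatter. Compound 4 is estimated at 65%, ranging from 40% to 90%.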

Compound 4, largest response reached (Emax), in percent of the reference or control that the assay uses: 110%
Compound 4: middle estimate off by 45 percentage points, on the low side, and the stated range ends below it.
By their numbers in this assay, from the lowest: compounds 3 and 2 (each within the scatter of the next); then compounds 1 and 4 (each within the scatter of the next).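

In this assay, the loss seen on going from a straight chain to a branched one is not general to this carbonyl carbon: 2-fluorocyclopropyl in place of isopropyl gives a number 39 percentage points higher from compound 2 to compound 4 (beyond the scatter). With 2-fluorocyclopropyl in place of propyl, the result is no change at the digits printed from compound 1 to compound 4 (within the scatter), so this ring-bearing group matches the straight chain here. Nothing at hand gives a reason for either step.

Whether the fluorine or the three-membered ring accounts for the rise stays open. Plain cyclopropyl and the other stereoisomers of 2-fluorocyclopropyl at this carbonyl carbon would be needed to separate them.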